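The source may report more compounds than this note shows. Statements on the series, on what has been measured and on what is new or still open speak of the compounds shown alone.

Measured so far in a toxicity assay on THP-1 cells (Homo sapiens) for inhibition; a higher number here means that more compound is tolerated, a lower number that less compound is tolerated:
- compound 1 `Cn1c(-c2cccc(Cl)c2)cnc1NC(=O)c1ccc(F)cc1`: compound 1 gives > 50000 nM, a limit of this assay.
- compound 2 `COc1ccc(-c2cnc(NC(=O)c3ccccc3OC)n2C)cc1`: compound 2 gives > 100000 nM, also a limit.
- compound 3 `COc1ccc(-c2cnc(NC(=O)c3cccc(Br)c3)n2C)cc1`: compound 3 gives > 100000 nM, again a limit.

Compound 1 stands at the limit of > 50000 nM in this assay, at which 1 of the 3 values shown sits, while the other two sit at the limit of > 100000 nM in this assay, at which 2 of the 3 values shown sit. Going by the values given here, the single one-place step, a step that the two limits leave unreadable from compound 2 to compound 3, is therefore unreadable.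

Compound 4 `Cc1ccc(-c2cnc(NC(=O)c3ccc(F)cc3)n2C)cc1` is not yet measured. Relative to compound 1 the change is 4-methylphenyl in place of 3-chlorophenyl on an aromatic carbon. Among the compounds with values here, no measured step touches this position, and the only step in hand is unreadable, so nothing points to a direction. Compound 4 is expected near the limits of the series, at 80000 nM, range 30000 nM to 200000 nM. The expected step that the limit leaves unreadable from compound 1 to compound 4 is none beyond the scatter.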

Compound 4, half-maximal cytotoxic concentration: 60000 nM
The estimate for compound 4 lay 1.3-fold (0.12 log units) above the measured number; low and high end bracket the measured number.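

No step can be read between compound 1 and compound 4: compound 1 stands at a limit, not a number. Still open, on these data alone, is whether 4-methylphenyl in place of 3-chlorophenyl shifts tolerated concentration at all, and what changes on the carbonyl carbon do.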